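The source may report more compounds than this note shows. Statements on the series, on what has been measured and on what is new or still open speak of the compounds shown alone.

Measured in an ADME assay on PBMC cells (Homo sapiens) for cytotoxicity, with a stated time of 5 days; a higher number here means a weaker inhibitor, a lower number a stronger inhibitor:
- compound 1 `[N-]=[N+]=N[C@H]1C[C@H](n2cnc3c(NC4CC4)nc(Cl)nc32)O[C@@H]1CO`: 35300 nM
- compound 2 `CN(C)c1nc(N)nc2c1ncn2[C@H]1C[C@H](N=[N+]=[N-])[C@@H](CO)O1`: > 100000 nM (a limit of the assay, not a number)

Compound 2 has no numerical value, only the limit of this assay. The position of compound 2 can be put no more exactly than this: the limit of > 100000 nM in this assay, at which 1 of the 2 values shown sits. For the measured compounds named here, compound 1 gives 35300 nM, the only true number so far.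

The next compound to be read is compound 3 `[N-]=[N+]=N[C@H]1C[C@H](n2cnc3c(NC4CC4)nc(N)nc32)O[C@@H]1CO`. It keeps the core of compound 2 and carries cyclopropylamino in place of dimethylamino on an aromatic carbon. Going by the values given here, no step between measured compounds isolates this change, so any expectation for it rests on little. A modest move toward a lower number in this assay is expected, and the reference for that is compound 1 at 35300 nM. The expected change is an at least 1.6-fold lower number from compound 2 to compound 3 (0.22 log units; that floor lies within the scatter). A result reported only as a limit would fit this expectation as well. For compound 3 the estimated value is 60000 nM, with an expected range of 20000 nM to 100000 nM.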

Compound 3, half-maximal inhibitory concentration: > 100000 nM
Compound 3: no number, only a limit; the forecaster's own chance of this, stated with the estimate: 45%; middle value at least 1.6-fold (0.22 log units) away from the limit.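

In this assay, for the compounds shown here, amino in place of chloro on an aromatic carbon, with cyclopropylamino and the rest of the core held constant, gives an at least 2.8-fold higher number from compound 1 to compound 3 (0.45 log units; beyond the scatter), the first readable step. Going by these compounds alone, the lower number in this pair therefore goes with chloro, and this single pair is the only evidence for that link. The step from dimethylamino to cyclopropylamino cannot be read, as both of its ends are limits of the assay, so the cyclopropylamino group shows no measurable change at this position, and the upper end of the series remains unresolved: the limit of > 100000 nM in this assay, at which 2 of the 3 values shown sit.

Any difference between dimethylamino and cyclopropylamino in this assay remains open, as does the true size of the step from chloro to amino, which has only a floor. Also open, from the compounds shown here alone, is where another group in the place of chloro, such as bromo or methoxy, would fall relative to the chloro and amino compounds, and whether a longer chain in place of cyclopropylamino would bring the values back within the measurable range.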